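The source may report more compounds than this note shows. Statements on the series, on what has been measured and on what is new or still open speak of the compounds shown alone.

Working notes on the series in a physicochemical assay for solubility; on this read-out lower numbers stand for lower solubility and higher numbers for higher solubility.

Compound 1 `CNC(=O)c1cc(C(=O)N[C@H]2[C@@H]3COC[C@@H]32)cc2c1OC[C@H]2c1ccccc1` gives a limit of the assay rather than a number: in this assay compound 1 reads >= 165 ug/mL. Compound 2 `CNC(=O)c1cc(C(=O)NC)c2c(c1)[C@](C)(c1ccccc1)CO2` likewise sits at a limit, reading >= 132 ug/mL in this assay. Compound 3 `CNC(=O)c1cc(C(=O)N[C@H]2[C@@H]3COC[C@@H]32)cc2c1OC[C@H]2c1cccc2[nH]ccc12` also reaches a limit, with >= 171 ug/mL in this assay. All three values shown are therefore lower bounds, as the lines (the limit of >= 132 ug/mL in this assay, at which 1 of the 3 values shown sits), the limit of >= 165 ug/mL in this assay, at which 1 of the 3 values shown sits, and the limit of >= 171 ug/mL in this assay, at which 1 of the 3 values shown sits, record, and compound 1 cannot be placed against compound 2 or compound 3 beyond that.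

Compound 4 `CCC(=O)N1C[C@@H]2[C@H](C1)[C@H]2NC(=O)c1cc(C(=O)NC)c2c(c1)[C@H](c1ccccc1)CO2` differs from compound 1 in one place: a group of 10 heavy atoms (8 carbon, 1 nitrogen, 1 oxygen; one three-membered non-aromatic ring of carbon only, one five-membered non-aromatic ring with 1 hetero atom) in place of a group of 6 heavy atoms (5 carbon, 1 oxygen; one three-membered non-aromatic ring of carbon only, one five-membered non-aromatic ring with 1 hetero atom), on an amide-type nitrogen. Going by the values given here, the one measured step, a step that the two limits leave unreadable from compound 1 to compound 3, changes a different part of the core and is itself unreadable, so no measured step reports on the present change. The step from compound 1 to compound 4 is therefore expected to be an at least 1.1-fold lower number from compound 1 to compound 4 (0.04 log units; that floor lies within the scatter), with no direction favoured beyond the scatter. Compound 4 is estimated to give 150 ug/mL in this assay, within a range from 50 ug/mL to 300 ug/mL, with a fair chance that only a limit is returned.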

Compound 4, solubility: >= 163 ug/mL
Compound 4: a limit, no number (the forecaster's own chance of this, stated with the estimate: 55%); middle value at least 1.0-fold (0.03 log units) from the limit.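

In this assay compound 4 gives >= 163 ug/mL, which is a limit, and compound 1 also stands at a limit, so no step can be read between compound 1 and compound 4. The compounds shown leave open whether the change on the amide-type nitrogen alters the read-out at all.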